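Triazole aryl group series, antiproliferative readout

The source may report more compounds than this note shows. Statements on the series, on what has been measured and on what is new or still open speak of the compounds shown alone.

Measured compounds:
Compound 1 `N#CC1=C(N)Oc2c(c3nc4ccccc4nc3c3ccccc23)C12C(=O)N(Cc1cnnn1-c1ccccc1Cl)c1ccccc12`: in an ADME assay on HUVEC cells (Homo sapiens) for antiproliferative activity, read by MTT assay, with a stated time of 48 h (a higher number here means a weaker inhibitor, a lower number a stronger inhibitor), compound 1 gives only a limit, > 50000 nM.
Compound 2 `N#CC1=C(N)Oc2c(c3nc4ccccc4nc3c3ccccc23)C12C(=O)N(Cc1cnnn1-c1cccc(Cl)c1)c1ccccc12`: in this assay compound 2 gives only a limit, > 50000 nM.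
Compound 3 `COc1ccccc1-n1nncc1CN1C(=O)C2(C(C#N)=C(N)Oc3c2c2nc4ccccc4nc2c2ccccc32)c2ccccc21`: in this assay compound 3 gives only a limit, > 50000 nM.

Compound 2 stands at the limit of this assay, and the two further values shown are limits as well, so compound 2 cannot be placed above or below either of them. Accordingly every measured step is unreadable: a step that the two limits leave unreadable from compound 1 to compound 2, a step that the two limits leave unreadable from compound 1 to compound 3 and a step that the two limits leave unreadable from compound 2 to compound 3. Going by the values given here, the only evidence is the limit of > 50000 nM in this assay, at which 3 of the 3 values shown sit.

Compound 4 `CC(=O)Nc1ccc(-n2nncc2CN2C(=O)C3(C(C#N)=C(N)Oc4c3c3nc5ccccc5nc3c3ccccc43)c3ccccc32)cc1` differs from compound 2 as follows: 4-acetamidophenyl in place of 3-chlorophenyl on an aromatic nitrogen. Among the compounds with values here, no measured step bears on this change in a readable way, so no direction beyond the scatter can be argued from the numbers. Given that all three measured compounds sit at the limit, compound 4 is expected to sit there too, with the step that the limit leaves unreadable from compound 2 to compound 4 expected to be unreadable. Compound 4 is therefore estimated at 70000 nM, in the range 20000 nM to 250000 nM, most likely reported again as a limit.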

Compound 4, half-maximal inhibitory concentration: > 50000 nM
Compound 4: only a limit was reported; the forecaster's own chance of this, stated with the estimate: 85%; the middle value does not contradict the limit.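

In this assay compound 4 gives only a limit, > 50000 nM, so its steps from compound 1, compound 2 and compound 3 cannot be read. The compounds shown leave open whether these aryl groups differ at all in this assay, as the only evidence is this: the limit of > 50000 nM in this assay, at which 4 of the 4 values shown sit.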